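A few compounds are considered here, and "the series" means these few. Any claim that something is new, unique, unknown or untested is made for them only; others in the source may bear on it.

Compound 3 `CCCCCc1cc(C(C)=O)c(O)cc1OCCCCC#N` carries a pentyl chain on the shared core of compound 1 `CC(=O)c1ccc(OCCCCC#N)cc1O`. In an assay on isolated protein for inhibition of leukotriene B4 receptor 1 (Homo sapiens), tested at 10 uM (on this read-out higher numbers stand for more inhibition at the one concentration tested (going by the name of the read-out) and lower numbers for less inhibition), compound 3 gives 31%, the second highest of the three numbers measured. Its nearest neighbour is compound 2 `CCCCc1cc(C(C)=O)c(O)cc1OCCCCC#N`, which in this assay gives 41%; the gap a number 10 percentage points lower from compound 2 to compound 3 (within the scatter) lies within the scatter. Compound 1 gives 0% in this assay, and the steps of a number 41 percentage points higher from compound 1 to compound 2 (beyond the scatter) and a number 31 percentage points higher from compound 1 to compound 3 (beyond the scatter) show that the butyl chain and the pentyl chain each raised the number by a large margin.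

Compound 4 `CC(=O)c1cc(CC2CO2)c(OCCCCC#N)cc1O` differs from compound 3 in one place: oxiran-2-yl in place of butyl on a saturated chain carbon bound to an aromatic carbon. Going by the values given here, no measured step tests this change directly. The steps of a number 41 percentage points higher from compound 1 to compound 2 (beyond the scatter) and a number 31 percentage points higher from compound 1 to compound 3 (beyond the scatter) bear on it in so far as they show that the number depends on what stands on that aromatic carbon, while the step of a number 10 percentage points lower from compound 2 to compound 3 (within the scatter) shows that one more chain carbon changes little. Compound 4 keeps the saturated chain carbon bound to the aromatic carbon but loses the butyl and gains the oxiran-2-yl ring, so a drop is expected, estimated at a number 16 percentage points lower from compound 3 to compound 4 (beyond the scatter). Compound 4 is therefore expected to give 15% in this assay, within a range from 0% to 40%.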

Compound 4, a percentage reported as inhibition, at one concentration (the size of the read-out at that concentration, not a potency): 62%
Compound 4: middle estimate off by 47 percentage points, on the low side; the measured number lies above the stated range.
By their numbers in this assay, from the lowest: compound 1; then compounds 3 and 2 (each within the scatter of the next); then compound 4.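

In this assay, the step of a number 62 percentage points higher from compound 1 to compound 4 (beyond the scatter) shows that (oxiran-2-yl)methyl on this aromatic carbon also raises the number from that of the bare core, and by a large margin. The earlier compounds shown here showed only that butyl and pentyl raise the number and that the two chains stand within the scatter of each other, whereas the steps of a number 31 percentage points higher from compound 3 to compound 4 (beyond the scatter) and a number 21 percentage points higher from compound 2 to compound 4 (beyond the scatter) show that the number at this place is not tied to a plain saturated chain: the oxiran-2-yl group, with its three heavy atoms, its three-membered ring and its one hydrogen-bond acceptor, outdoes both chains. No measurement here accounts for this rise.

The compounds shown leave open whether the gain rests on the ring or on its oxygen, which a cyclopropyl group or a methoxy group on the same saturated chain carbon could begin to separate. They also leave open whether the ring must stay intact, a question that a 1,2-dihydroxyethyl group in its place would address, and how these single-concentration numbers relate to potency.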